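The compounds below may be only part of what the source reports. "The series", "measured", "known", "first", "only" and "open" are said of these compounds alone.

Compound 1 `O=C(Nc1ccc(Cl)c(Cl)c1)Nc1cc2ncncc2cc1OCc1cccc(F)c1` and compound 2 `O=C(Nc1cc2ncncc2cc1OCc1cccc(F)c1)Nc1cccc2ccccc12` share one core and differ only in the group on an amide-type nitrogen. In a functional assay on GBM1 cells (Homo sapiens) for antiproliferative activity, read by WST assay, with a stated time of 72 h (a lower number here means a stronger inhibitor, a higher number a weaker inhibitor), compound 1 gives 2100 nM, while compound 2 gives 1300 nM; the step of a 1.6-fold lower number from compound 1 to compound 2 (0.21 log units; within the scatter) lies within the scatter. Of the two numbers, that of compound 2 is the smaller, but compound 1 sits within the scatter of it, so the two cannot be told apart on potency. Compound 3 `O=C(Nc1cc2ncncc2cc1OCc1ccc(Cl)cc1)Nc1cccc2ccccc12` keeps the naphthalen-1-yl group of compound 2 and changes the other end: 4-chlorophenyl in place of 3-fluorophenyl on a saturated chain carbon bound to an oxygen on an aromatic ring. Among the compounds with values here, no measured step touches this position; the only step known concerns a different group and is itself within the scatter. With nothing bearing on the change, the step of no change at the digits printed from compound 2 to compound 3 (within the scatter) is expected to stay within the scatter in this assay. Compound 3 is therefore estimated at 1300 nM, with a range from 450 nM to 3800 nM.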

Compound 3, half-maximal inhibitory concentration: 7900 nM
The estimate for compound 3 lay 6.1-fold (0.78 log units) below the measured number, and the stated range ends below it.
By their numbers in this assay, from the lowest: compounds 2 and 1 (each within the scatter of the next); then compound 3.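

Within the data shown here, the (3-fluorobenzyl)oxy end is the first place where a change moves the number in this assay beyond the scatter: a 6.1-fold higher number from compound 2 to compound 3 (0.78 log units; beyond the scatter). The step is modest, but it shows that this position is not indifferent to the group it carries, even though 3-fluorophenyl and 4-chlorophenyl match in heavy atoms, hydrogen-bond donors and acceptors, and charge. Nothing available bears on why the number rises.

The halogen and its place on the ring change together in this one step, so the compounds shown do not separate the two; 3-chlorophenyl, 4-fluorophenyl or plain phenyl at this carbon would bear on that. They also leave open whether the same change would give a similar step with the 3,4-dichlorophenyl group of compound 1 on the amide-type nitrogen.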